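Carbamate ester variations on a shared core

The source may report more compounds than this note shows. Statements on the series, on what has been measured and on what is new or still open speak of the compounds shown alone.

Three compounds with a shared core differ only in the group on an oxygen next to a carbonyl group. Compound 1 `Cc1nc(S(C)(=O)=O)ccc1Oc1ncnc(OC2CCN(C(=O)OC3CCC3)CC2)c1F` carries a cyclobutyl there and gives 13.6 nM in a functional assay on isolated protein for inhibition of Glucose-dependent insulinotropic receptor (Homo sapiens), read by HTRF and cAMP accumulation; a lower number here means that less compound is needed, a higher number that more compound is needed for the effect. Compound 2 `Cc1nc(S(C)(=O)=O)ccc1Oc1ncnc(OC2CCN(C(=O)OC(C)(C)C#N)CC2)c1F` carries a 1-cyano-1-methylethyl and gives 92.9 nM in this assay. Compound 3 `Cc1nc(S(C)(=O)=O)ccc1Oc1ncnc(OC2CCN(C(=O)O[C@H](C)C(F)(F)F)CC2)c1F` carries a 1-(trifluoromethyl)ethyl and gives 9.2 nM, the lowest of the three numbers; its nearest neighbour is compound 1, and a 1.5-fold lower number from compound 1 to compound 3 (0.17 log units; within the scatter) is within the scatter, while a 10-fold lower number from compound 2 to compound 3 (1.00 log units; beyond the scatter) and a 6.8-fold higher number from compound 1 to compound 2 (0.83 log units; beyond the scatter) lie beyond it.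

Compound 4 `Cc1nc(S(C)(=O)=O)ccc1Oc1ncnc(OC2CCN(C(=O)OC3(C(F)(F)F)CCC3)CC2)c1F` is the next step: 1-(trifluoromethyl)cyclobutyl in place of 1-(trifluoromethyl)ethyl on an oxygen next to a carbonyl group. It combines the four-membered ring of compound 1 with the trifluoromethyl of compound 3. The step that bears on it most is a 1.5-fold lower number from compound 1 to compound 3 (0.17 log units; within the scatter), which shows that replacing cyclobutyl by 1-(trifluoromethyl)ethyl changed little. Only the nitrile-bearing group of compound 2 moved the number clearly. Merging a four-membered ring with a trifluoromethyl is therefore expected to leave the number where compound 3 stands, with a 1.2-fold lower number from compound 3 to compound 4 (0.06 log units; within the scatter) inside the scatter. For compound 4 the estimate in this assay is 8 nM, with a range from 4 nM to 18 nM.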

Compound 4, half-maximal effective concentration: 14.3 nM
For compound 4 the middle estimate is 1.8-fold (0.25 log units) below the measured one; low and high end bracket the measured number.
By their numbers in this assay, from the lowest: compounds 3, 1 and 4 (each within the scatter of the next); then compound 2.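

Compound 4 shows that this position on an oxygen next to a carbonyl group accepts trifluoromethyl in place of hydrogen on a saturated ring carbon of the cyclobutyl with no reading change in this assay (a 1.1-fold higher number from compound 1 to compound 4 (0.02 log units; within the scatter)), and the exchange of the open 1-(trifluoromethyl)ethyl, with its defined stereocentre, for the 1-(trifluoromethyl)cyclobutyl, which has no such centre, also stays within the scatter (a 1.6-fold higher number from compound 3 to compound 4 (0.19 log units; within the scatter)). Compounds 1, 3 and 4 thus form a group of three within the scatter of one another, and the 1-cyano-1-methylethyl of compound 2 stands apart from a third member as well (a 6.5-fold lower number from compound 2 to compound 4 (0.81 log units; beyond the scatter)), so among these four compounds only that group separates clearly. Nothing in the data shown offers an explanation for these numbers.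

The compounds shown leave open whether the flat response holds for a five-membered carbon ring such as cyclopentyl, for a ring carrying oxygen such as oxetanyl, or for a longer chain on the same oxygen. They also leave open whether a nitrile on a cyclobutyl, or an amine at this place, would move the number as far as the group of compound 2 does.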